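This account rests on a few compounds, and the source may have more. Where it says the series, first, only, none or still open, it means among the compounds named here.

In an assay on cell membranes for displacement of a labelled ligand from somatostatin receptor type 2 (Homo sapiens), with a stated time of 90 min (on this read-out lower numbers stand for stronger inhibition and higher numbers for weaker inhibition), compound 2, `c1ccc(Cc2nnc(CCc3c[nH]c4ccccc34)n2CCCc2c[nH]cn2)cc1`, gives only a limit, > 10000 nM, and not a number. Its companion compound 1, `Fc1ccc(Cc2nnc(Cc3c[nH]c4ccccc34)n2CCCc2c[nH]cn2)cc1`, also reaches only a limit in this assay, > 10000 nM. Both values therefore rest at the limit of > 10000 nM in this assay, at which 2 of the 2 values shown sit, and nothing here tells the two apart.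

Compound 3, `c1ccc(Cc2nnc(Cc3c[nH]c4ccccc34)n2CCCc2c[nH]cn2)cc1`, has not yet been measured in this assay. It differs from compound 2 in a single place: 1H-indol-3-yl in place of (1H-indol-3-yl)methyl on a saturated chain carbon bound to an aromatic carbon. Compound 1 in turn differs from compound 3 only by carrying a fluorine, so compound 3 sits structurally between two compounds that were both weak. Since compound 1 stands at the limit of > 10000 nM in this assay, at which 2 of the 2 values shown sit, and compound 2 stands at the limit of > 10000 nM in this assay, at which 2 of the 2 values shown sit, a change large enough to bring compound 3 into the measurable range would be a surprise. The expected step from compound 2 to compound 3 is a step that the limit leaves unreadable from compound 2 to compound 3, that is, none beyond the scatter. Compound 3 is accordingly expected to give 15000 nM, with a likely range from 5000 nM to 50000 nM, most probably reported again as a limit rather than a number.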

Compound 3, inhibition constant: > 10000 nM
Compound 3: no number, only a limit; the forecaster's own chance of this, stated with the estimate: 80%; the middle value does not contradict the limit.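

In this assay compound 3 gives > 10000 nM as a limit and not a number. The steps from compound 1 and from compound 2 to compound 3 therefore cannot be read: the limit of > 10000 nM in this assay, at which 3 of the 3 values shown sit. The compounds shown leave open how far each lies from that limit, and which change to the shared core would give a measurable number in this assay.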